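Chloro for methoxy on a thiazolidinone para-substituted aryl ring

A few compounds are considered here, and "the series" means these few. Any claim that something is new, unique, unknown or untested is made for them only; others in the source may bear on it.

Compound 1 `COc1ccc(C2SCC(=O)N2CCN2CCCCC2)cc1` and compound 2 `Cc1ccc(C2SCC(=O)N2CCN2CCCCC2)cc1` share one core and differ only in the group on the aromatic carbon. In an ADME assay on Vero cells (Chlorocebus sabaeus) for cytotoxicity, read by neutral red uptake, tested at 12.3 ug/mL (on this read-out lower numbers stand for a stronger effect and higher numbers for a weaker effect at the one concentration tested), compound 1 gives 100%, and compound 2 gives 100%. Compound 1 therefore stands level with compound 2 at the digits shown, the step of no change at the digits printed from compound 1 to compound 2 (within the scatter) lying within the scatter. Compound 3 `O=C1CSC(c2ccc(Cl)cc2)N1CCN1CCCCC1` has not been measured; it differs from compound 1 by chloro in place of methoxy on an aromatic carbon. Among the measured compounds shown here, the only measured step at this position, from methoxy to methyl, left the read-out unchanged, and nothing else bears on the change. A step of no change at the digits printed from compound 1 to compound 3 (within the scatter) is therefore expected, meaning no change beyond the scatter. Compound 3 is expected to give 100% in this assay, with the likely range from 85% to 105%.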

Compound 3, a percentage reported as activity, at one concentration (the size of the read-out at that concentration, not a potency): 90%
For compound 3 the middle estimate is 10 percentage points above the measured one, within the range that was stated.
By their numbers in this assay, from the lowest: compounds 3, 1 and 2 (each within the scatter of the next).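

In this assay, chloro, a single chlorine atom with no hydrogen-bond acceptor, now joins methoxy and methyl on this aromatic carbon para to a large group. The replacement of methoxy gives a number 10 percentage points lower from compound 1 to compound 3 (within the scatter) and that of methyl gives a number 10 percentage points lower from compound 2 to compound 3 (within the scatter) in this comparison, so all three listed groups stand within the scatter of one another at this one concentration, a finding that now extends beyond the single methoxy-to-methyl step. No supporting measurement is available to explain this result.

From the compounds shown here alone, whether an amine or a carboxylic acid on the same carbon would also stay within the scatter remains open. The compounds shown also leave open how changes elsewhere on the shared core, such as a longer chain in place of the two-carbon link, would read in this assay.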